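Swapping methoxy for fluoro on the aryl amide

The source may hold more compounds than are shown below. What is called first, only, known or untested is meant among the compounds shown, and "the series" means these compounds.

Of the compounds shown here, three built on one shared core have been measured in a functional assay on CHO cells for agonist activity at Melanocyte-stimulating hormone receptor (Homo sapiens), read by a luciferase reporter, with a stated time of 4 h; a higher number here means that more compound is needed for the effect, a lower number that less compound is needed. Compound 1 `CC(C)N(C(=O)CN1C=CN(c2ccccc2)C(=O)C(Cc2n[nH]c3ccccc23)C1=O)c1ccc(F)cc1` gives 50.1 nM. Compound 2 `CC(C)N(C(=O)CN1C=CN(C)C(=O)C(Cc2n[nH]c3cc(F)ccc23)C1=O)c1ccc(F)cc1` gives 3720 nM. Compound 3 `COc1ccc(N(C(=O)CN2C=CN(c3ccccc3)C(=O)C(Cc3n[nH]c4cc(F)ccc34)C2=O)C(C)C)cc1` gives 1.59 nM, the lowest of the three numbers; its gap to compound 1 and its far larger gap to compound 2 both lie beyond the usual scatter. Among the compounds with values here, neither of those pairs differs from compound 3 in a single place, so they show values but no clean step.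

Compound 4 `CC(C)N(C(=O)CN1C=CN(c2ccccc2)C(=O)C(Cc2n[nH]c3cc(F)ccc23)C1=O)c1ccc(F)cc1` is compound 3 with one alteration: fluoro in place of methoxy on an aromatic carbon. Compound 1 carries the same 4-fluorophenyl group yet lacks the fluoro on the indazole, so its number does not isolate this change. The expectation is that compound 4 will need somewhat more compound than compound 3, with the step of a 5.0-fold higher number from compound 3 to compound 4 (0.70 log units; beyond the scatter) judged as a modest loss that may not clear the scatter. Compound 4 is therefore estimated at 8 nM, within a range from 2 nM to 50 nM.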

Compound 4, half-maximal effective concentration: 14.1 nM
Compound 4: middle estimate off by 1.8-fold (0.25 log units), on the low side; measured number inside the range.
By their numbers in this assay, from the lowest: compound 3; then compound 4; then compound 1; then compound 2.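

Within the data shown here, compound 4 gives the first clean reading at this position: in this assay, replacing 4-methoxyphenyl with 4-fluorophenyl gives an 8.9-fold higher number from compound 3 to compound 4 (0.95 log units; beyond the scatter), so the para substituent on this ring matters and methoxy gives the lower number of the two. Compound 4 also makes two other changes readable, each with everything else held constant. Fluoro in place of hydrogen on an aromatic carbon gives a 3.6-fold lower number from compound 1 to compound 4 (0.55 log units; beyond the scatter), a modest step, while phenyl in place of methyl on the amide-type nitrogen in a ring gives a 260-fold lower number from compound 2 to compound 4 (2.42 log units; beyond the scatter), a large one.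

On these data alone, how a chloro, hydroxyl or ethoxy group would fare at the para position remains open. Nothing available here explains why any of these three changes shifts the number.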